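A few compounds are considered here, and "the series" means these few. Any claim that something is new, unique, unknown or untested is made for them only; others in the source may bear on it.

Of the compounds shown here, three built on one shared core have been measured in an ADME assay on MT4 cells (Homo sapiens) for cytotoxicity, read by MTT assay; a lower number here means that less compound is tolerated, a higher number that more compound is tolerated. Compound 1 `CCOC(=O)/C(O)=C/C(=O)c1cn(Cc2cc(F)c(F)c(F)c2)c2cccc(OC)c12` gives 33400 nM, compound 2 `CCOC(=O)/C(O)=C/C(=O)c1cn(Cc2ccc(F)c(F)c2)c2cccc(OC)c12` gives 125000 nM, and compound 3 `COc1cccc2c1c(C(=O)/C=C(\O)C(=O)O)cn2Cc1cc(F)ccc1F` gives 46200 nM. Compound 3 thus stands second highest of the three: its number sits within the usual scatter of that of compound 1, while compound 2 lies higher by an amount beyond the scatter. Among the measured compounds shown here, the only step that can be traced between two measured neighbours is a 3.7-fold higher number from compound 1 to compound 2 (0.57 log units; beyond the scatter), brought about by a hydrogen in place of fluoro on an aromatic carbon. Compound 4 `COc1cccc2c1c(C(=O)/C=C(\O)C(=O)O)cn2Cc1ccc(F)cc1` has not yet been measured; it differs from compound 3 by 4-fluorophenyl in place of 2,5-difluorophenyl on a saturated chain carbon bound to an aromatic nitrogen. This change likewise removes a fluoro from an aromatic carbon, though it also moves where the remaining fluorine sits, and compound 1 and compound 2 differ from compound 3 elsewhere in their make-up as well, so the earlier step is only a partial guide. On that basis a modest rise in this assay is expected for compound 4, of roughly a 1.7-fold higher number from compound 3 to compound 4 (0.24 log units; within the scatter). Compound 4 is therefore estimated at 80000 nM, with a likely range from 35000 nM to 200000 nM.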

Compound 4, half-maximal cytotoxic concentration: 41100 nM
The estimate for compound 4 lay 1.9-fold (0.29 log units) above the measured number; the range from low to high includes it.
By their numbers in this assay, from the lowest: compounds 1, 4 and 3 (each within the scatter of the next); then compound 2.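

In this assay, putting 4-fluorophenyl in place of 2,5-difluorophenyl on a saturated chain carbon bound to an aromatic nitrogen gives a 1.1-fold lower number from compound 3 to compound 4 (0.05 log units; within the scatter) and so leaves the tolerated concentration unchanged within the usual scatter, even though the ring loses a fluorine and the remaining fluorine sits elsewhere. Among the compounds shown here, the only earlier step, a 3.7-fold higher number from compound 1 to compound 2 (0.57 log units; beyond the scatter), also took one fluoro off this ring but went beyond the scatter, so the loss of a fluorine from this ring does not bring a clear shift in every case, and the rise seen in that first pair cannot be treated as a general rule for this position. The data on hand offer no measurement that explains why the two steps differ in size.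
The compounds shown all keep at least one fluorine on this ring, so it remains open whether a plain phenyl, with no fluorine at all, or a chloro group in place of fluoro would also stay within the scatter of compound 3. Also open, on these data alone, is how a longer chain between the ring and the aromatic nitrogen, or an amine on the ring, would read in this assay.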